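Chain exchange from compound 3 to compound 4

A few compounds are considered here, and "the series" means these few. Any claim that something is new, unique, unknown or untested is made for them only; others in the source may bear on it.

Measured in a functional assay on Lewis lung carcinoma cells for antiproliferative activity against Lewis lung carcinoma cell line (Mus musculus), read by CCK-8 assay, with a stated time of 48 h; a higher number here means a weaker inhibitor, a lower number a stronger inhibitor:
- compound 1 `O=C(CCCCCCC(=O)NCCNc1nonc1/C(=N/O)Nc1ccc(F)c(Br)c1)NO`: 56600 nM
- compound 2 `O=C(CCCCC(=O)NCCNc1nonc1/C(=N/O)Nc1ccc(F)c(Br)c1)NO`: > 100000 nM (a limit)
- compound 3 `O=C(CCCCCC(=O)NCCNc1nonc1/C(=N/O)Nc1ccc(F)c(Br)c1)NO`: 90100 nM

Among the compounds with values here, the series has only two actual numbers, and they do not separate: a 1.6-fold higher number from compound 1 to compound 3 (0.20 log units; within the scatter). Compound 2 gives > 100000 nM, which is a limit of the assay and not a number.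

Going on to compound 4 `O=C(CCCC(=O)NCCNc1nonc1/C(=N/O)Nc1ccc(F)c(Br)c1)NO`, hydroxycarbamoyl takes the place of 2-(hydroxycarbamoyl)ethyl on a saturated chain carbon, three bonds along the chain from a carbonyl carbon (hydroxycarbamoyl in place of 2-(hydroxycarbamoyl)ethyl on a saturated chain carbon, three bonds along the chain from a carbonyl carbon). Within the data shown here, the closest precedent is the same exchange made four bonds along the chain, which gave an at least 1.7-fold higher number from compound 1 to compound 2 (0.24 log units; that floor lies within the scatter). From the compounds shown here alone, that step is only a floor, so its full size is unknown. The remaining step, an at least 1.1-fold lower number from compound 2 to compound 3 (0.04 log units; that floor lies within the scatter), is a smaller exchange and also gives only a floor.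

A step of similar size towards a higher number is therefore expected in this assay, and the expected step is a 1.7-fold higher number from compound 3 to compound 4 (0.22 log units; within the scatter). The assay is expected to report only a limit for this compound in most repeats. For compound 4 the estimated value is 150000 nM, with an expected range from 80000 nM to 400000 nM.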

Compound 4, half-maximal inhibitory concentration: > 100000 nM
Compound 4: no number, only a limit; the forecaster's own chance of this, stated with the estimate: 75%; the middle value does not contradict the limit.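

In this assay the exchange three bonds along the chain from a carbonyl carbon yields only floors, an at least 1.1-fold higher number from compound 3 to compound 4 (0.04 log units; that floor lies within the scatter) and an at least 1.7-fold higher number from compound 1 to compound 4 (0.24 log units; that floor lies within the scatter), so no loss beyond the scatter is established at this position. The exchange of 2-(hydroxycarbamoyl)ethyl for hydroxycarbamoyl has now been read twice, and neither reading gives a full size: the same change on two cores in this assay, an at least 1.7-fold higher number (0.24 log units; that floor lies within the scatter) from compound 1 to compound 2 and an at least 1.1-fold higher number (0.04 log units; that floor lies within the scatter) from compound 3 to compound 4; the limit leaves it open whether they differ Compound 2 and compound 4 each give a limit of the assay and not a number, and the step between them cannot be read: the limit of > 100000 nM in this assay, at which 2 of the 4 values shown sit.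

Within the data shown here, still open is whether chain length matters at all in this assay, as the only two numbers, for compound 1 and compound 3, lie within the scatter of each other. Also open, from the compounds shown here alone, is how a longer chain than that of compound 1, or a carboxylic acid in place of hydroxycarbamoyl, would read here.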